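Swapping a methyl for fluorine on a pyridine ether

The source may report more compounds than this note shows. Statements on the series, on what has been measured and on what is new or still open speak of the compounds shown alone.

Of the compounds shown here, two from the same family have been tested in an assay on membranes from brain for displacement of a labelled ligand from Neuronal acetylcholine receptor; alpha4/beta2 (Rattus norvegicus); a lower number here means a stronger inhibitor, a higher number a weaker inhibitor. Compound 1, `CN1CCC[C@H]1COc1cccnc1Br`, gives 451 nM. Compound 2, `Cc1cncc(OC[C@@H]2CCCN2C)c1`, gives 0.48 nM, the lowest of the two numbers and a step beyond the scatter from compound 1. The next compound, compound 3, is `CN1CCC[C@H]1COc1cncc(F)c1`. It differs from compound 2 in one place: fluoro in place of methyl on an aromatic carbon. Among the compounds with values here, no step between two measured compounds with such a change is available, so the size of the effect has to be guessed from the groups involved. Both groups are small and neither adds a hydrogen-bond donor or acceptor, so the expected change in this assay is small, probably none beyond the scatter, and if anything a slight weakening: a 2.1-fold higher number from compound 2 to compound 3 (0.32 log units; beyond the scatter). Compound 3 is therefore expected to give about 1 nM in this assay, within a range from 0.3 nM to 4 nM.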

Compound 3, inhibition constant: 0.69 nM
Compound 3: the middle estimate sits 1.4-fold (0.16 log units) above what was measured; the measured number falls inside the stated range.
By their numbers in this assay, from the lowest: compounds 2 and 3 (each within the scatter of the next); then compound 1.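

In this assay, fluoro in place of methyl on this aromatic carbon, two atoms from the ring nitrogen, gives a 1.4-fold higher number from compound 2 to compound 3 (0.16 log units; within the scatter), so this pair shows no real difference between the two groups. Within the data shown here, this is the first single-place comparison in the family, since compound 1 and compound 2 differ in more than one place and could not show what one group at this carbon does. Nothing available explains why the two groups give matching numbers.

Going by these compounds, both groups are small, so it remains open whether the same carbon would accept something larger or quite different, such as an amine, a carboxylic acid or a longer chain. Also open, on these data alone, is what plain hydrogen at this carbon would give, which would show whether either group matters at all.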